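Swapping the aromatic group on a weak antiproliferative compound

The compounds below may be only part of what the source reports. "The series", "measured", "known", "first", "only" and "open" are said of these compounds alone.

- compound 1 `O=C1NC(O)(CCn2cnc3cc[nH]c3c2=O)C(OCc2ccccc2)=C1OCc1ccccc1`: 92000 nM
- compound 2 `O=C1O/C(=C\Cn2cnc3cncc(Br)c32)C(OCc2ccccc2)=C1OCc1ccccc1`: 15000 nM
- compound 3 `COc1nc(OC)c2c(ccn2C/C=C2\OC(=O)C(OCc3ccccc3)=C2OCc2ccccc2)n1`: 12000 nM

In a functional assay on HeLa cells (Homo sapiens) for antiproliferative activity, read by MTT assay, with a stated time of 72 h (on this read-out lower numbers stand for stronger inhibition and higher numbers for weaker inhibition), compound 1 gives 92000 nM, the highest of the three numbers and so the weakest inhibition measured here. The numbers for the other two compounds both lie lower, and both gaps to compound 1 go beyond the usual scatter.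

The next molecule is compound 4 `Nc1nc(F)c(Cl)c2c1ncn2CCC1(O)NC(=O)C(OCc2ccccc2)=C1OCc1ccccc1`, which keeps the rest of compound 1 and exchanges only the aromatic group at the end of the chain: a group of 12 heavy atoms (6 carbon, 4 nitrogen, 1 fluorine, 1 chlorine; one five-membered aromatic ring with 2 hetero atoms, one six-membered aromatic ring with 1 hetero atom) in place of a group of 10 heavy atoms (6 carbon, 3 nitrogen, 1 oxygen; one five-membered aromatic ring with 1 hetero atom, one six-membered aromatic ring with 2 hetero atoms), on a saturated chain carbon, two bonds along the chain from a saturated ring carbon. For the measured compounds named here, no pair of measured compounds isolates a change of this kind, so any forecast rests on indirect evidence. Compound 2 at 15000 nM and compound 3 at 12000 nM also carry aromatic groups different from that of compound 1, but they differ from it elsewhere in the molecule too. Only part of their gap can therefore be expected to carry over.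

The expected change in this assay is a moderate fall, estimated as a 3.7-fold lower number from compound 1 to compound 4 (0.57 log units; beyond the scatter). For compound 4 the expected value is 25000 nM, with an estimated range of 7000 nM to 90000 nM.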

Compound 4, half-maximal inhibitory concentration: 39000 nM
Estimate against measurement, compound 4: 1.6-fold (0.19 log units) below; the range from low to high includes it.
By their numbers in this assay, from the lowest: compounds 3 and 2 (each within the scatter of the next); then compound 4; then compound 1.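

For the compounds shown here, this is the first comparison in which only one place changes: on the saturated chain carbon, exchanging one aromatic group for the other gives a 2.4-fold lower number from compound 1 to compound 4 (0.37 log units; beyond the scatter) in this assay. The earlier compounds shown here could not show this, since compounds 2 and 3 differ from compound 1 elsewhere in the molecule as well as in the aromatic group, whereas here the rest of compound 1 stays the same, so the modest gain in inhibition belongs to this exchange alone. No measurement is available that explains why the new group gives a lower number.

The entering group differs from the leaving one in several ways at once, including its fluorine, its chlorine and the hetero atoms in its rings, so this single step cannot say which of these features matters, or whether any one of them does. The compounds shown also leave open how a longer chain carrying the same aromatic group would behave, and what an amine on that saturated chain carbon, in place of either aromatic group, would do to the number.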